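Hydrazone aryl swap on the shared core: compound 4

The source may report more compounds than this note shows. Statements on the series, on what has been measured and on what is new or still open speak of the compounds shown alone.

Compound 3 `Cc1cc(NN=C2CCC(C)n3c2ncc(C(=O)O)c3=O)ccc1Br` sits at the limit of a functional assay on the whole organism with Rattus norvegicus as the target; a lower number here means that less compound is needed, a higher number that more compound is needed for the effect: in this assay compound 3 gives > 100 umol/kg, which is a limit of the assay and not a number. Compound 2 `CC1CCC(=NNc2cc(Cl)cc(Cl)c2)c2ncc(C(=O)O)c(=O)n21` rests at the same limit, giving > 100 umol/kg in this assay. Among the compounds with values here, compound 1 `CC1CCC(=NNc2ccccc2)c2ncc(C(=O)O)c(=O)n21` is the only member of the series with a measured number; in this assay compound 1 gives 1.2 umol/kg. Both readable steps run from phenyl to a halogen-bearing ring and are large losses: an at least 83-fold higher number from compound 1 to compound 2 (1.92 log units; beyond the scatter) and an at least 83-fold higher number from compound 1 to compound 3 (1.92 log units; beyond the scatter). The step that the two limits leave unreadable from compound 2 to compound 3 cannot be sized because both of its ends rest at the limit of > 100 umol/kg in this assay, at which 2 of the 3 values shown sit.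

Compound 4 `CC1CCC(=NNc2ccccn2)c2ncc(C(=O)O)c(=O)n21` differs from compound 3 in one place: pyridin-2-yl in place of 4-bromo-3-methylphenyl on an amine nitrogen. Within the data shown here, the entering pyridin-2-yl carries neither bromine nor methyl nor chlorine, so in what it bears it stands closer to the phenyl of compound 1 than to the rings of compound 2 or compound 3; the hetero atom in the ring has no counterpart among the measured compounds, so the expectation stays wide and a further limit remains possible. The step of an at least 20-fold lower number from compound 3 to compound 4 (1.30 log units; beyond the scatter) is therefore expected to be a recovery toward the level of compound 1. Compound 4 is estimated at 5 umol/kg in this assay, with a range from 1 umol/kg to 60 umol/kg.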

Compound 4, dose for 50% inhibition: > 100 umol/kg
Compound 4 gave a limit, no number (the forecaster's own chance of this, stated with the estimate: 25%); middle value at least 20-fold (1.30 log units) away from the limit.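

In this assay compound 4 gives > 100 umol/kg, which is a limit of the assay and not a number. Replacing phenyl with pyridin-2-yl on the amine nitrogen gives an at least 83-fold higher number from compound 1 to compound 4 (1.92 log units; beyond the scatter); the earlier large losses came with rings bearing chlorine, or bromine and methyl, whereas this one comes with a ring that bears none of these, so a halogen or methyl on the ring is not required for a loss at this position, and the phenyl of compound 1 remains the only ring here that gives a number rather than a limit. The steps among compound 2, compound 3 and compound 4 cannot be read because their ends all rest at the same limit: the limit of > 100 umol/kg in this assay, at which 3 of the 4 values shown sit.

The compounds shown do not tell whether the loss in compound 4 belongs to a ring nitrogen as such or to its place in the ring, which pyridin-3-yl or pyridin-4-yl on the same amine nitrogen would address. They also leave open how much a single small group on the phenyl ring, such as 4-fluorophenyl or 4-methylphenyl, is tolerated, and how far compound 2, compound 3 and compound 4 really lie from one another.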